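A few compounds are considered here, and "the series" means these few. Any claim that something is new, unique, unknown or untested is made for them only; others in the source may bear on it.

Measured so far in an assay on BaF3 cells for inhibition of proto-oncogene tyrosine-protein kinase receptor Ret (Homo sapiens), read by MTT assay, with a stated time of 48 h; a lower number here means a stronger inhibitor of growth, a higher number a weaker inhibitor of growth:
Compound 1 `CC(C)n1nc(-c2cc(C3CCCCC3)on2)c2c(N)ncnc21` gives 9500 nM.
Compound 2 `CC(C)n1nc(-c2cc(C(C)(C)C)on2)c2c(N)ncnc21` gives 6120 nM.
Compound 3 `Nc1ncnc2c1c(-c1cc(C3CC3)on1)nn2C1CCOCC1` gives 440 nM.

Compound 2 stands second highest of these three numbers; its nearest neighbour is compound 1, and the step of a 1.6-fold lower number from compound 1 to compound 2 (0.19 log units; within the scatter) lies within the scatter, while compound 3 sits far lower. Compound 4 `CC(C)c1cc(-c2nn(C(C)C)c3ncnc(N)c23)no1` differs from compound 2 by hydrogen in place of methyl on a saturated chain carbon bound to an aromatic carbon and two saturated chain carbons. Within the data shown here, no measured step removes a methyl in this way; the only single-place step, a 1.6-fold lower number from compound 1 to compound 2 (0.19 log units; within the scatter), swapped one group there for another and produced nothing beyond the scatter. Compound 3 carries a cyclopropyl there but also a different group on the core, so its lower number cannot be tied to one change. The expected step in this assay is therefore small, a 1.4-fold lower number from compound 2 to compound 4 (0.13 log units; within the scatter), with no clear direction. Compound 4 is estimated at 4500 nM, within 1500 nM to 13000 nM.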

Compound 4, concentration for 50% growth inhibition: 2400 nM
Compound 4: middle estimate off by 1.9-fold (0.27 log units), on the high side; measured number inside the range.
By their numbers in this assay, from the lowest: compound 3; then compound 4; then compounds 2 and 1 (each within the scatter of the next).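

Taking one methyl away, tert-butyl to isopropyl, gives a 2.6-fold lower number from compound 2 to compound 4 (0.41 log units; beyond the scatter) in this assay, so a small change at this place can move the number beyond the scatter, which the swap of cyclohexyl for tert-butyl did not do. Isopropyl in place of cyclohexyl on an aromatic carbon gives a 4.0-fold lower number from compound 1 to compound 4 (0.60 log units; beyond the scatter), which points the same way. On these data alone, whether ethyl or an amine on this aromatic carbon would give a lower number still stays open. Nothing measured here explains why the number falls with isopropyl.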